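The compounds below may be only part of what the source reports. "The series", "measured", "known", "first", "only" and "open" are said of these compounds alone.

Among the compounds with values here, compound 1, with the structure `CCCCCCc1cc(C(C)=O)c(O)cc1OCCCCC#N`, is one of two compounds measured in an assay on isolated protein for inhibition of leukotriene B4 receptor 1 (Homo sapiens), tested at 10 uM; on this read-out lower numbers stand for less inhibition and higher numbers for more inhibition at the one concentration tested (going by the name of the read-out). In this assay compound 1 gives 51%, the lower of the two numbers. Compound 2, with the structure `CSCc1cc(C(C)=O)c(O)cc1OCCCCCCC#N`, gives 97% in this assay, a number higher than that of compound 1 by more than the usual scatter of such measurements. These two compounds differ in several places at once, so no single change can be tied to that gap.

Compound 3, with the structure `C=CCc1cc(C(C)=O)c(O)cc1OCCCCC#N`, has not yet been measured in this assay. It differs from compound 1 in one place only: vinyl in place of pentyl on a saturated chain carbon bound to an aromatic carbon. Within the data shown here, no pair of measured compounds shows this kind of change, so there is no step to lean on, and the direction of the effect is open. Within that uncertainty the expectation is that compound 3 comes out a little lower than compound 1, a step of a number 11 percentage points lower from compound 1 to compound 3 (beyond the scatter) in this assay. Compound 3 is therefore estimated at 40%, with a likely range from 15% to 65%.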

Compound 3, a percentage reported as inhibition, at one concentration (the size of the read-out at that concentration, not a potency): 92%
Compound 3: middle estimate off by 52 percentage points, on the low side; measured number outside the range, above it.
By their numbers in this assay, from the lowest: compound 1; then compounds 3 and 2 (each within the scatter of the next).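

Putting vinyl in place of pentyl on a saturated chain carbon bound to an aromatic carbon gives a number 41 percentage points higher from compound 1 to compound 3 (beyond the scatter) in this assay. Within the data shown here, this is the first single change that can be read on its own, and it shows that this position matters for the read-out: with the rest of the molecule unchanged, the group here accounts for a large shift. It also shows that the longer hexyl chain of compound 1 is not needed for a high number, as the shorter allyl group of compound 3 carries a double bond outside the aromatic ring and still reaches a high inhibition at the one concentration tested, though nothing at hand explains why the number rises.

This one step combines two changes, a shorter chain and a new double bond, so the compounds shown cannot tell which of them matters; a saturated propyl group at this position would separate the two. As far as these compounds go, it also remains open whether a butyl chain, or a chain ending in an amine or a carboxylic acid, would keep the number high.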